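This account rests on a few compounds, and the source may have more. Where it says the series, first, only, none or still open, it means among the compounds named here.

Three esters built on one shared core have been tested in a functional assay on MGC-803 cells (Homo sapiens) for inhibition, read by MTT assay; on this read-out lower numbers stand for stronger inhibition and higher numbers for weaker inhibition. Compound 1 `C=C1C(=O)[C@@]23C(=O)OC[C@]4([C@@H](OC(C)=O)CCC(C)(C)[C@H]4C=O)[C@@H]2CC[C@H]1[C@H]3OC(=O)c1ccc(C(F)(F)F)cc1` gives 5540 nM, compound 2 `C=C1C(=O)[C@@]23C(=O)OC[C@]4([C@@H](OC(C)=O)CCC(C)(C)[C@H]4C=O)[C@@H]2CC[C@H]1[C@H]3OC(C)=O` gives 3470 nM, and compound 3 `C=C1C(=O)[C@@]23C(=O)OC[C@]4([C@@H](OC(C)=O)CCC(C)(C)[C@H]4C=O)[C@@H]2CC[C@H]1[C@H]3OC(=O)c1ccc([N+](=O)[O-])cc1` gives 1980 nM, the lowest of the three numbers, although a 1.8-fold lower number from compound 2 to compound 3 (0.24 log units; within the scatter) and only a 2.8-fold lower number from compound 1 to compound 3 (0.45 log units; beyond the scatter). Compound 4 `C=C1C(=O)[C@@]23C(=O)OC[C@]4([C@@H](OC(C)=O)CCC(C)(C)[C@H]4C=O)[C@@H]2CC[C@H]1[C@H]3OC(=O)CCCC` differs from compound 3 by butyl in place of 4-nitrophenyl on a carbonyl carbon. Within the data shown here, the steps that bear on this exchange of an aromatic group for a chain are a 1.8-fold lower number from compound 2 to compound 3 (0.24 log units; within the scatter), where methyl gave way to 4-nitrophenyl, and a 1.6-fold lower number from compound 1 to compound 2 (0.20 log units; within the scatter); both were small. Going back from an aromatic group to a chain is therefore expected to raise the number slightly, if at all beyond the scatter, and the estimated step is a 1.8-fold higher number from compound 3 to compound 4 (0.25 log units; within the scatter). Compound 4 is expected to give about 3500 nM, within 1500 nM to 8000 nM.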

Compound 4, half-maximal inhibitory concentration: 2490 nM
Estimate against measurement, compound 4: 1.4-fold (0.15 log units) above; the range from low to high includes it.
By their numbers in this assay, from the lowest: compounds 3, 4, 2 and 1 (each within the scatter of the next, the first and the last beyond it).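

On this carbonyl carbon a ring is not required: a plain butyl chain matches 4-nitrophenyl within the scatter (a 1.3-fold higher number from compound 3 to compound 4 (0.10 log units; within the scatter)), and propyl in place of hydrogen on the saturated chain carbon also stays within it (a 1.4-fold lower number from compound 2 to compound 4 (0.14 log units; within the scatter)). Only the 4-(trifluoromethyl)phenyl ester stands apart from the butyl ester, by a modest margin (a 2.2-fold lower number from compound 1 to compound 4 (0.35 log units; beyond the scatter)). No supporting data explain that gap. As far as these compounds go, whether a longer chain, or a chain ending in an amine or a carboxylic acid, would shift the number remains open.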